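Working notes: difluorophenyl in place of dimethoxyphenyl

The source may report more compounds than this note shows. Statements on the series, on what has been measured and on what is new or still open speak of the compounds shown alone.

Measured so far:
compound 1 `COc1ccc(-c2cc(/C=C/C(=O)c3ccc(N)cc3)[nH]n2)cc1` — 11100 nM
compound 2 `COc1cc(-c2cc(/C=C/C(=O)c3ccc(Cl)c(Cl)c3)[nH]n2)cc(OC)c1OC` — > 100000 nM, a limit of the assay
compound 3 `COc1ccc(C(=O)/C=C/c2cc(-c3cc(OC)c(OC)c(OC)c3)n[nH]2)cc1OC` — 5460 nM

In a functional assay on CAKI-1 cells (Homo sapiens) for inhibition, read by sulforhodamine B assay, with a stated time of 48 h (on this read-out higher numbers stand for weaker inhibition of growth and lower numbers for stronger inhibition of growth), compound 3 holds the lowest of the two numbers shown; compound 1 gives a higher number, a gap beyond the scatter. Compound 2 sits at the limit (the limit of > 100000 nM in this assay, at which 1 of the 3 values shown sits).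

Compound 4 `COc1cc(-c2cc(/C=C/C(=O)c3ccc(F)c(F)c3)[nH]n2)cc(OC)c1OC` differs from compound 3 in one place: 3,4-difluorophenyl in place of 3,4-dimethoxyphenyl on a carbonyl carbon. Among the measured compounds shown here, the only measured step bearing on this change is an at least 18-fold lower number from compound 2 to compound 3 (1.26 log units; beyond the scatter), where a dihalogenated ring gave way to the dimethoxyphenyl. Compound 4 moves back to a dihalogenated ring, so a higher number in this assay is expected, its size uncertain because one end of that step is a limit (the limit of > 100000 nM in this assay, at which 1 of the 3 values shown sits). Compound 4 is estimated at 30000 nM, between 8000 nM and 100000 nM. The estimate corresponds to an expected step of a 5.5-fold higher number from compound 3 to compound 4 (0.74 log units; beyond the scatter).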

Compound 4, concentration for total growth inhibition: > 100000 nM
Compound 4: only a limit was reported (the forecaster's own chance of this, stated with the estimate: 35%); at least 3.3-fold (0.52 log units) between middle value and limit.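

In this assay, 3,4-dimethoxyphenyl on the carbonyl carbon now stands apart from two dihalogenated rings rather than one, with an at least 18-fold higher number from compound 3 to compound 4 (1.26 log units; beyond the scatter). The result for the dichlorophenyl ring therefore does not stand alone: replacing its chlorines with fluorines on this ring does not recover the number of compound 3. Compound 4 reads only as a limit, as does compound 2, so the step between them cannot be read and the two halogenated rings cannot be ranked: the limit of > 100000 nM in this assay, at which 2 of the 4 values shown sit.

Still open, from the compounds shown here alone, is whether both methoxy groups are needed. A phenyl, a monomethoxyphenyl or a dimethylaminophenyl group at this place on the core of compound 3 would test that.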